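Working notes: ethyl in place of the ring phenyl

This account rests on a few compounds, and the source may have more. Where it says the series, first, only, none or still open, it means among the compounds named here.

Measured so far in a functional assay on MCF7 cells (Homo sapiens) for inhibition, read by MTT assay, with a stated time of 48 h; on this read-out lower numbers stand for stronger inhibition and higher numbers for weaker inhibition:
- compound 1 `C=C1C(=O)N(c2ccccc2)N(C)C1c1ccc(OC)cc1` gives 75000 nM
- compound 2 `C=C1C(=O)N(c2ccccc2)N(C)C1c1ccccc1` gives 84400 nM

Compound 2 has the highest of the two numbers; its nearest neighbour is compound 1, and the step of a 1.1-fold higher number from compound 1 to compound 2 (0.05 log units; within the scatter) lies within the scatter, so the two compounds cannot be ordered against each other on this read-out.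

Compound 3 `C=C1C(=O)N(c2ccccc2)N(C)C1CC` is not yet measured. It differs from compound 2 by ethyl in place of phenyl on a saturated ring carbon. Among the compounds with values here, the only measured step, from compound 1 to compound 2, concerns a substituent on the phenyl that is now removed altogether, and it was within the scatter; it gives no direct guidance on exchanging the phenyl itself for ethyl. Within the data shown here, no measured pair shows the effect of such a change in this assay. With nothing to anchor a direction, the working expectation for compound 3 is a step of a 1.2-fold higher number from compound 2 to compound 3 (0.07 log units; within the scatter) that does not go beyond the scatter, with a wide allowance either way. The estimate for compound 3 in this assay is 100000 nM, in the range 30000 nM to 300000 nM.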

Compound 3, half-maximal inhibitory concentration: 185000 nM
For compound 3 the middle estimate is 1.9-fold (0.27 log units) below the measured one; the measured number falls inside the stated range.
By their numbers in this assay, from the lowest: compounds 1 and 2 (each within the scatter of the next); then compound 3.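

In this assay, within the data shown here, the exchange of phenyl for ethyl on the saturated ring carbon gives a 2.2-fold higher number from compound 2 to compound 3 (0.34 log units; beyond the scatter), a modest change, and the first step that lies beyond the scatter. This position therefore registers a change of group, whereas the exchange of methoxy for hydrogen on the aromatic carbon, a 1.1-fold higher number from compound 1 to compound 2 (0.05 log units; within the scatter), did not separate its pair. The phenyl-to-ethyl change removes the aromatic ring and shortens the group in a single exchange, so the step cannot be assigned to either alteration, and nothing available here accounts for it.

Open, going by these compounds, is whether a saturated ring such as cyclohexyl, or a longer chain such as butyl, on this carbon would give a number close to that of compound 2 or close to that of compound 3, which would help separate the loss of the aromatic ring from the shortening of the group. Also open, on these data alone, is whether an amine or a carboxylic acid on the phenyl of compound 2 would move the number beyond the scatter, as the methoxy exchange did not.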